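Three Inactive Enones and a Fourth Awaiting Measurement

The compounds below may be only part of what the source reports. "The series", "measured", "known", "first", "only" and "open" are said of these compounds alone.

Compound 1, `Cc1ccc(S(=O)(=O)/C(=C/c2c(O)cc(O)cc2O)C(=O)c2ccc(Br)cc2)cc1`, gives in a functional assay on DU-145 cells (Homo sapiens) for inhibition, read by trypan blue exclusion, with a stated time of 96 h (a lower number here means a stronger inhibitor of growth, a higher number a weaker inhibitor of growth), the limit > 100000 nM.
Compound 2, `Cc1ccc(S(=O)(=O)/C(=C/c2ccc(F)cc2F)C(=O)c2ccc(Br)cc2)cc1`, gives in this assay the limit > 100000 nM.
Compound 3, `Cc1ccc(S/C(=C/c2c(O)cc(O)cc2O)C(=O)c2ccc(Br)cc2)cc1`, gives in this assay the limit > 100000 nM.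

Each of these values is a limit of this assay and not a number, as the limit of > 100000 nM in this assay, at which 3 of the 3 values shown sit, shows. The change from compound 1 to compound 2 is 2,4-difluorophenyl in place of 2,4,6-trihydroxyphenyl on a double-bonded chain carbon bound to a double-bonded chain carbon. Its step, a step that the two limits leave unreadable from compound 1 to compound 2, has no readable size; both of its ends sit at the limit of > 100000 nM in this assay, at which 3 of the 3 values shown sit. The two cores differ by (4-methylphenyl)sulfanyl in place of (4-methylphenyl)sulfonyl on a double-bonded chain carbon bound to a carbonyl carbon and a double-bonded chain carbon, and the step that the two limits leave unreadable from compound 1 to compound 3 is likewise unreadable.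

Compound 4, `Cc1ccc(S/C(=C/c2ccc(F)cc2F)C(=O)c2ccc(Br)cc2)cc1`, is still to be measured. It differs from compound 3 by 2,4-difluorophenyl in place of 2,4,6-trihydroxyphenyl on a double-bonded chain carbon bound to a double-bonded chain carbon, the same change as that from compound 1 to compound 2, made at the same place. For compound 4 the expected step is a step that the limit leaves unreadable from compound 3 to compound 4, again not readable. This rests on compound 1 and compound 2 both sitting at the limit of > 100000 nM in this assay, at which 3 of the 3 values shown sit. Compound 4 is estimated at 150000 nM, with a range from 60000 nM to 400000 nM.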

Compound 4, concentration for 50% growth inhibition: > 100000 nM
Compound 4 was reported as a limit; the forecaster's own chance of this, stated with the estimate: 85%; the middle value is on the limit's open side.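

Compound 4 gives > 100000 nM in this assay as a limit and not a number, so no new step can be read from compound 3 to compound 4: (the limit of > 100000 nM in this assay, at which 4 of the 4 values shown sit). The compounds shown leave open how far any of the four lies beyond that limit, and whether either change affects growth inhibition.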